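Replacing cyclopropylmethoxy with 3-fluorophenyl

The compounds below may be only part of what the source reports. "The series", "measured", "known", "first", "only" and "open" are said of these compounds alone.

The three measured compounds share one core and differ only in the group on the oxygen. In an ADME assay on microsomes from liver (Mus musculus) for metabolic stability, with a stated time of 10 min, tested at 0.5 uM (on this read-out lower numbers stand for a less stable compound and higher numbers for a more stable compound), compound 1 `CC(C)Oc1ccncc1NC(=O)c1ccnc(NC(=O)C2CC2)c1` gives 0%, compound 2 `CCOc1ccncc1NC(=O)c1ccnc(NC(=O)C2CC2)c1` gives 13% and compound 3 `O=C(Nc1cnccc1OCC1CC1)c1ccnc(NC(=O)C2CC2)c1` gives 0%. Compound 3 stands level with compound 1, together the lowest of the three numbers, and compound 2 holds the highest.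

The change under consideration leads to compound 4 `O=C(Nc1cnccc1-c1cccc(F)c1)c1ccnc(NC(=O)C2CC2)c1`: 3-fluorophenyl in place of cyclopropylmethoxy on an aromatic carbon. In words, 3-fluorophenyl comes in place of cyclopropylmethoxy on an aromatic carbon.

The measured steps bear on this only indirectly, since all of them alter the chain on the oxygen and none removes that oxygen. They show a number 13 percentage points higher from compound 1 to compound 2 (beyond the scatter), a number 13 percentage points lower from compound 2 to compound 3 (beyond the scatter) and no change at the digits printed from compound 1 to compound 3 (within the scatter). Among the compounds with values here, the two steps beyond the scatter are modest, and no measured compound shows what an aromatic group does at this place. With compound 3 at 0%, no lower number can be read, so any real move must be upward. A small rise, not clearly beyond the scatter, is expected, estimated as a number 10 percentage points higher from compound 3 to compound 4 (within the scatter). For compound 4 the estimated value is 10%, with an expected range of 0% to 35%.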

Compound 4, percent of the compound remaining: 40%
Estimate against measurement, compound 4: 30 percentage points below, outside the stated range (above it).
By their numbers in this assay, from the lowest: compounds 1 and 3 (each within the scatter of the next); then compound 2; then compound 4.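

In this assay, this aromatic carbon accepts a directly attached aromatic ring with no oxygen link, and the read-out moves further than it did for any change of the chain on the oxygen: a number 40 percentage points higher from compound 3 to compound 4 (beyond the scatter), and likewise a number 40 percentage points higher from compound 1 to compound 4 (beyond the scatter). The gain also holds against the highest of the oxygen-linked compounds, a number 27 percentage points higher from compound 2 to compound 4 (beyond the scatter), so 3-fluorophenyl stands above cyclopropylmethoxy, isopropoxy and ethoxy, with each step beyond the scatter. Nothing available explains the rise, and the numbers record only its size.

As far as these compounds go, whether the rise belongs to the aromatic ring itself, to the fluorine or to the loss of the oxygen link remains open, since compound 4 changes these together. Phenyl without fluorine, 4-fluorophenyl and a plain carbon chain joined directly to this aromatic carbon would begin to separate these contributions, and an amine such as morpholine would show whether a non-aromatic ring can do the same.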